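Cyclohexyl ester in the allyl-guaiacol benzoate series

The source may report more compounds than this note shows. Statements on the series, on what has been measured and on what is new or still open speak of the compounds shown alone.

The series shares one core, with an ester on the phenol and variation in the acid part. Compound 1 `C=CCc1ccc(OC(=O)c2ccc(F)cc2)c(OC)c1` gives 2.7 in a physicochemical assay for lipophilicity; on this read-out lower numbers stand for lower lipophilicity and higher numbers for higher lipophilicity. Compound 2 `C=CCc1ccc(OC(=O)c2ccc(Cl)cc2)c(OC)c1` gives 2.79, and compound 3 `C=CCc1ccc(OC(=O)c2ccccc2Cl)c(OC)c1` gives 2.79. Compound 2 stands level with compound 3 at the digits shown, the two together at the top of the three numbers, with compound 1 the furthest from it; the step of a number 0.09 log units higher from compound 1 to compound 2 (within the scatter) stays within the scatter, as does no change at the digits printed from compound 2 to compound 3 (within the scatter).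

Compound 4 `C=CCc1ccc(OC(=O)C2CCCCC2)c(OC)c1` is not yet measured. It differs from compound 2 by cyclohexyl in place of 4-chlorophenyl on a carbonyl carbon. Among the measured compounds shown here, none of the measured steps covers an exchange of this kind: the steps of a number 0.09 log units higher from compound 1 to compound 2 (within the scatter), a number 0.09 log units higher from compound 1 to compound 3 (within the scatter) and no change at the digits printed from compound 2 to compound 3 (within the scatter) all concern halogen or its placement on an aromatic ring, and all lie within the scatter. They therefore give only the baseline, not a direction, for this change. A modest rise is expected for compound 4, of about a number 0.21 log units higher from compound 2 to compound 4 (within the scatter), but with wide uncertainty. The estimate for compound 4 in this assay is 3, expected to fall between 2.5 and 3.5.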

Compound 4, partition coefficient: 3.52
For compound 4 the middle estimate is 0.52 log units below the measured one; measured number outside the range, above it.
By their numbers in this assay, from the lowest: compounds 1, 2 and 3 (each within the scatter of the next); then compound 4.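

In this assay cyclohexyl in place of an aromatic ring on a carbonyl carbon gives steps beyond the scatter (a number 0.73 log units higher from compound 2 to compound 4 (beyond the scatter); a number 0.73 log units higher from compound 3 to compound 4 (beyond the scatter); a number 0.82 log units higher from compound 1 to compound 4 (beyond the scatter)). Among compound 1, compound 2 and compound 3, changing the halogen or its placement gave only steps within the scatter, so this position responds measurably to the exchange of the whole ring, from one six-membered aromatic ring of carbon only to one six-membered non-aromatic ring of carbon only. No evidence at hand accounts for the size of these steps.

On these data alone, whether the rise is particular to cyclohexyl remains open, since a cyclopentyl, a tert-butyl or a longer alkyl chain on the carbonyl carbon could behave differently. Also open, as far as these compounds go, is how far an amine or a carboxylic acid on the cyclohexyl ring would move the number.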